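The compounds below may be only part of what the source reports. "The series", "measured", "known", "first", "only" and "open" are said of these compounds alone.

In a functional assay on PC-3 cells (Homo sapiens) for antiproliferative activity, read by MTT assay, with a stated time of 72 h (on this read-out lower numbers stand for stronger inhibition and higher numbers for weaker inhibition), two compounds of this series have so far been tested, and neither returned a number. Compound 1 `O=C1OCC[C@@H]1NC(=S)SCCOc1cccc2ccccc12` reached only the limit of the assay, > 64000 nM. Compound 2 `CC(C)c1ccc(NCC(=O)N[C@H]2CCOC2=O)cc1` likewise stopped at the limit of the assay, > 64000 nM. Compound 2 therefore stands exactly where the whole measured set stands: the limit of > 64000 nM in this assay, at which 2 of the 2 values shown sit. No pair of measured compounds differs in a single place, so no measured step exists to follow, and the position of compound 2 among the numbers shown is simply that limit. Compound 3 `O=C(CNc1ccccc1)N[C@H]1CCOC1=O` is the nearest unmeasured relative of compound 2 and differs from it in one place: hydrogen in place of isopropyl on an aromatic carbon. With both measured values sitting at the limit, nothing measured points in either direction for a change of this kind. Compound 3 is expected to give 90000 nM in this assay, with a range from 30000 nM to 250000 nM. The step that the limit leaves unreadable from compound 2 to compound 3 that this estimate means is expected to be none beyond the usual scatter. Compound 3 is thus expected to remain at the limit as well.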

Compound 3, half-maximal inhibitory concentration: > 64000 nM
Compound 3: no number, only a limit; the forecaster's own chance of this, stated with the estimate: 85%; the middle value is on the limit's open side.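

In this assay, among these compounds, compound 2 and compound 3 each gave only a limit and no number, so the exchange of isopropyl for hydrogen yields no step that can be read. The compounds shown leave open what change, if any, would bring this series to a measurable value: the limit of > 64000 nM in this assay, at which 3 of the 3 values shown sit.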